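This account rests on a few compounds, and the source may have more. Where it says the series, first, only, none or still open, it means among the compounds named here.

Measured compounds in a functional assay on OVCAR-3 cells (Homo sapiens) for inhibition, read by sulforhodamine B assay, with a stated time of 48 h; a lower number here means a stronger inhibitor, a higher number a weaker inhibitor:
compound 1 `COc1cc(-c2nn(-c3cccc(NC(=O)Nc4cc(C(F)(F)F)cc(C(F)(F)F)c4)c3)cc2-c2ccncc2)ccc1Cl` gives 410 nM
compound 2 `COc1cc(-c2nn(-c3cccc(NC(=O)Nc4ccc(Cl)c(Cl)c4)c3)cc2-c2ccncc2)ccc1Cl` gives 700 nM
compound 3 `O=C(Nc1cccc(-n2cc(-c3ccncc3)c(-c3ccc(Cl)c(O)c3)n2)c1)Nc1ccc(Cl)c(Cl)c1` gives 1050 nM

Compound 4 `O=C(Nc1cccc(-n2cc(-c3ccncc3)c(-c3ccc(Cl)c(O)c3)n2)c1)Nc1cc(C(F)(F)F)cc(C(F)(F)F)c1` is not yet measured. Compound 1 and compound 2 carry different groups on the urea; the difference between the two cores is not broken down here. Compound 2 and compound 3 differ in one place, (hydrogen in place of methyl on an oxygen on an aromatic ring), and the step is a 1.5-fold higher number from compound 2 to compound 3 (0.18 log units; within the scatter). The change from compound 1 to compound 4 is the same one, (hydrogen in place of methyl on an oxygen on an aromatic ring), at the same place on the same ring. Compound 1 and compound 2 lie within the scatter of each other in this assay; the gap from compound 1 to compound 3 lies beyond it.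

For compound 4 in this assay a step like the earlier one is expected, because the step of a 1.5-fold higher number from compound 2 to compound 3 (0.18 log units; within the scatter) lies within the scatter, and the expected step from compound 1 is a 1.5-fold higher number from compound 1 to compound 4 (0.17 log units; within the scatter). The estimate for compound 4 is 600 nM, with a range from 300 nM to 1300 nM. This rests on a single measured pair, so the range is kept wide.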

Compound 4, half-maximal inhibitory concentration: 400 nM
The estimate for compound 4 lay 1.5-fold (0.18 log units) above the measured number; the range from low to high includes it.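

In this assay, the change from methoxy to hydroxy on the 4-chloro-3-methoxyphenyl group gives a 1.0-fold lower number from compound 1 to compound 4 (0.01 log units; within the scatter), and the same change on the other core gives a step that cannot be told apart from it: the same change on two cores in this assay, a 1.5-fold higher number (0.18 log units; within the scatter) from compound 2 to compound 3 and a 1.0-fold lower number (0.01 log units; within the scatter) from compound 1 to compound 4, 1.5-fold (0.19 log units) apart, within the scatter of two such steps. On the two cores shown, the change therefore carries over without a detectable difference, and in neither case does it move the number beyond the scatter. This rests on two pairs in one cell assay, so it does not show that the same would hold with other groups on the urea or in any other measurement, and it gives no cause for the small steps.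

The compounds shown leave open whether an ethoxy group or an amine at the same place on the ring would also stay within the scatter. Also open, going by these compounds, is how the change behaves on a core with a nitrile or a single chlorine on the urea's aryl ring.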